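Replacing dimethylcarbamoyl with fluoro in compound 1

The source may hold more compounds than are shown below. What is called first, only, known or untested is meant among the compounds shown, and "the series" means these compounds.

Measured so far in a physicochemical assay for lipophilicity, using the shake flask method, at pH 7.4; a lower number here means a more polar compound, a higher number a more lipophilic compound:
- compound 1 `CCCC(Oc1ccc(-n2cc(C(=O)N(C)C)cn2)cc1)c1ccc(C(=O)NCCC(=O)O)cc1`: 0.5
- compound 2 `CCC(Oc1ccc(-n2cc(C(F)(F)F)cn2)cc1)c1ccc(C(=O)NCCC(=O)O)cc1`: 1.9
- compound 3 `O=C(O)CCNC(=O)c1ccc(C(Oc2ccc(-n3cc(C(F)(F)F)cn3)cc2)C2CCCC2)cc1`: 3.3

Of these three, compound 1 stands lowest at 0.5, and compound 2 and compound 3 both lie beyond the scatter above it. The unmeasured compound 4 `CCCC(Oc1ccc(-n2cc(F)cn2)cc1)c1ccc(C(=O)NCCC(=O)O)cc1` keeps the core of compound 1 and changes one group: fluoro in place of dimethylcarbamoyl on an aromatic carbon.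

Among the measured compounds shown here, no measured step covers this exchange. For the measured compounds named here, the only step available, a number 1.40 log units higher from compound 2 to compound 3 (beyond the scatter), is large, but it is cyclopentyl in place of ethyl on a saturated chain carbon, so it shows only how far a single change can move the numbers. The closest guide is compound 2, which has trifluoromethyl on the aromatic carbon in question and ethyl where compound 1 has propyl. Compound 2 gives 1.9. Resting on that value of compound 2 at 1.9, a rise beyond the scatter is expected in this assay. The expected step is large and upward, a number 1.30 log units higher from compound 1 to compound 4 (beyond the scatter). Compound 4 is expected at 1.8, with an estimated range from 1.3 to 2.3.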

Compound 4, distribution coefficient: 2
Estimate against measurement, compound 4: 0.20 log units below; low and high end bracket the measured number.
By their numbers in this assay, from the lowest: compound 1; then compounds 2 and 4 (each within the scatter of the next); then compound 3.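

In this assay, fluoro in place of dimethylcarbamoyl on an aromatic carbon of the five-membered aromatic ring gives a number 1.50 log units higher from compound 1 to compound 4 (beyond the scatter), with the propyl chain and the rest of the core of compound 1 left as they stand. Among the compounds shown here, until now the only step that could be read lay on the saturated chain carbon, so this result adds a second place where a single exchange moves the number by a large amount: the substituent on the five-membered aromatic ring matters in this assay as well. The data record the size and direction of this move but offer no measurement that explains it, and they cannot divide the step between the departure of dimethylcarbamoyl and the arrival of fluoro.

The compounds shown leave open where a nitrile, an amine or a plain hydrogen on this carbon would fall in this assay on the core of compound 1. They also leave open whether the same exchange would give a step of similar size with ethyl or cyclopentyl on the chain carbon in place of propyl.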